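A few compounds are considered here, and "the series" means these few. Any claim that something is new, unique, unknown or untested is made for them only; others in the source may bear on it.

Working notes on the chalcone series.

Compound 1 `COc1cc(O)c(CC=C(C)C)c(O)c1C(=O)/C=C/c1ccc(Cl)cc1` and compound 3 `COc1cc(O)cc(O)c1C(=O)/C=C/c1ccc(Cl)cc1` share a chalcone framework carrying a 4-chlorophenyl unit; their cores differ by hydrogen in place of 3-methylbut-2-en-1-yl on an aromatic carbon. In a functional assay on HeLa cells (Homo sapiens) for inhibition, read by MTT assay, with a stated time of 72 h (on this read-out lower numbers stand for stronger inhibition and higher numbers for weaker inhibition), compound 1 gives 16500 nM, and compound 3 gives 17000 nM; the step of a 1.0-fold higher number from compound 1 to compound 3 (0.01 log units; within the scatter) shows that the two cores behave alike in this measurement.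

Compound 2 `COc1cc(O)c(CC=C(C)C)c(O)c1C(=O)/C=C/c1ccc([N+](=O)[O-])cc1` is the nitro counterpart of compound 1. The change nitro in place of chloro on an aromatic carbon gives in this assay a value for compound 2 of 29700 nM, and the step of a 1.8-fold higher number from compound 1 to compound 2 (0.26 log units; within the scatter) is small.

Compound 4 `COc1cc(O)cc(O)c1C(=O)/C=C/c1ccc([N+](=O)[O-])cc1` carries the same change nitro in place of chloro on an aromatic carbon on the core of compound 3. The place of the change is the same in both pairs, so the change from compound 3 to compound 4 is the same change as from compound 1 to compound 2, now made on the other core. The two cores gave matching numbers in the pair compound 1 against compound 3. The measured step of a 1.8-fold higher number from compound 1 to compound 2 (0.26 log units; within the scatter) in this assay is therefore taken as the guide for the other core. The estimated step on that core is a 1.8-fold higher number from compound 3 to compound 4 (0.25 log units; within the scatter). The expected value for compound 4 in this assay is 30000 nM, with an estimated range from 15000 nM to 60000 nM. Going by the values given here, the expectation rests on only one measured instance of this change, so a wider outcome cannot be excluded.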

Compound 4, half-maximal inhibitory concentration: > 50000 nM
Compound 4: only a limit was reported (the forecaster's own chance of this, stated with the estimate: 5%); middle value at least 1.6-fold (0.22 log units) from the limit.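

In this assay, going by these compounds alone, compound 4 gives > 50000 nM, which is a limit of the assay and not a number, and it is the only such value in this set: the limit of > 50000 nM in this assay, at which 1 of the 4 values shown sits. On these data alone, on the core without the 3-methylbut-2-en-1-yl group, nitro in place of chloro gives an at least 2.9-fold higher number from compound 3 to compound 4 (0.46 log units; beyond the scatter), so on this core the change has a measurable cost, but the true size of the step stays unknown, and the notes cannot say whether the change carries over unaltered from the other core: the same change on two cores in this assay, a 1.8-fold higher number (0.26 log units; within the scatter) from compound 1 to compound 2 and an at least 2.9-fold higher number (0.46 log units; beyond the scatter) from compound 3 to compound 4; the limit leaves it open whether they differ. Read the other way, loss of the 3-methylbut-2-en-1-yl group among the nitro compounds gives an at least 1.6-fold higher number from compound 2 to compound 4 (0.22 log units; that floor lies within the scatter), and this floor shows neither that the two cores part ways in the nitro pair nor that they stay alike as they do in the chloro pair: the same change on two cores in this assay, a 1.0-fold higher number (0.01 log units; within the scatter) from compound 1 to compound 3 and an at least 1.6-fold higher number (0.22 log units; that floor lies within the scatter) from compound 2 to compound 4; the limit leaves it open whether they differ.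

The compounds shown leave open where the value of compound 4 really lies, and so whether the effect of the change depends on the core at all. They also leave open whether an amine or a carboxylic acid in place of the chloro, or a longer chain in place of the 3-methylbut-2-en-1-yl group, would follow the same course on both cores.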